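Chloro in place of bromo on an aromatic carbon

The compounds below may be only part of what the source reports. "The series", "measured", "known", "first", "only" and "open" are said of these compounds alone.

Among the measured compounds shown here, in a functional assay on the whole organism with Mus musculus as the target (on this read-out higher numbers stand for an effect only at larger amounts of compound and lower numbers for an effect already at smaller amounts), compound 1 `O=C(/C=C1\CCc2ccccc21)NC1CC1` gives 150 mg/kg and compound 2 `NC(=O)/C=C1\CCc2ccc(Br)cc21` gives 96 mg/kg as the only two numbers so far. These values lie within the usual scatter of each other, so compound 2 cannot be told apart from compound 1 on the present data. Compound 3 `NC(=O)/C=C1\CCc2ccc(Cl)cc21` has not yet been measured. It differs from compound 2 in one place, chloro in place of bromo on an aromatic carbon with chloro in place of bromo on an aromatic carbon of a six-membered aromatic ring of carbon only. For the measured compounds named here, no measured pair shows this exchange, so the expectation rests on compound 2 at 96 mg/kg alone. In this assay the expected change is a 1.0-fold higher number from compound 2 to compound 3 (0.02 log units; within the scatter) and is estimated to stay within the scatter, with no clear direction. Compound 3 is expected at 100 mg/kg with an estimated range from 50 mg/kg to 200 mg/kg as its outer ends.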

Compound 3, dose for half-maximal effect: 98 mg/kg
Compound 3: middle estimate off by 1.0-fold (0.01 log units), on the high side, within the range that was stated.
By their numbers in this assay, from the lowest: compounds 2, 3 and 1 (each within the scatter of the next).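

Among the compounds shown here, with this assay as the read-out, the exchange of bromo for chloro gives a 1.0-fold higher number from compound 2 to compound 3 (0.01 log units; within the scatter), the first step that can be read at a single place. On this aromatic carbon, meta to a fused ring and para to a fused ring, the two halogens therefore cannot be told apart, and the whole-organism dose read-out does not separate them while the rest of the structure stays the same. Nothing at hand bears on why the two compounds read alike.

The compounds shown leave open whether this carbon tolerates any group other than these two halogens, such as a methoxy group, an amine or a carboxylic acid. They also leave open whether hydrogen at this carbon would read any differently from chloro or bromo on the same primary amide.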